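Outlook for Compound 4

The compounds below may be only part of what the source reports. "The series", "measured", "known", "first", "only" and "open" are said of these compounds alone.

In a physicochemical assay for solubility, using the shake flask method, with a stated time of 48 h, at pH 6.5 (on this read-out lower numbers stand for lower solubility and higher numbers for higher solubility), compound 1 `N#Cc1ccccc1-c1cc(-c2cc(Cl)cc(OCCC(F)(F)F)c2)c(=O)n(-c2cccnc2)c1` gives 25 ug/mL. In this assay compound 2 `Cc1ocnc1COc1cc(Cl)cc(-c2cc(-c3ccccc3C#N)cn(-c3cccnc3)c2=O)c1` gives 13.1 ug/mL. In this assay compound 3 `Cn1cc(-c2cc(-c3cc(Cl)cc(OCCC(F)(F)F)c3)c(=O)n(-c3cccnc3)c2)c(=O)[nH]c1=O` gives 57 ug/mL.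

Compound 3 holds the highest of the three numbers; its nearest neighbour is compound 1 and its furthest compound 2, both steps beyond the scatter. Compound 4 `Cn1cc(-c2cc(-c3cc(Cl)cc(OCc4scnc4C(F)(F)F)c3)c(=O)n(-c3cccnc3)c2)c(=O)[nH]c1=O` changes compound 3 in one place: a group of 9 heavy atoms (4 carbon, 1 nitrogen, 3 fluorine, 1 sulfur; one five-membered aromatic ring with 2 hetero atoms) in place of a group of 5 heavy atoms (2 carbon, 3 fluorine; no ring), on a saturated chain carbon bound to an oxygen on an aromatic ring. The step that bears on it is a 1.9-fold lower number from compound 1 to compound 2 (0.28 log units; within the scatter), where a five-membered aromatic ring with 2 hetero atoms also replaced the 2,2,2-trifluoroethyl at the same place. The entering group here is larger still, so compound 4 is expected to move down, perhaps slightly beyond the scatter, as a 2.3-fold lower number from compound 3 to compound 4 (0.36 log units; beyond the scatter). Compound 4 is therefore estimated at 25 ug/mL, within 8 ug/mL to 60 ug/mL.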

Compound 4, solubility: 24.8 ug/mL
For compound 4 the middle estimate is 1.0-fold (0.00 log units) above the measured one; the measured number falls inside the stated range.
By their numbers in this assay, from the lowest: compounds 2, 4 and 1 (each within the scatter of the next); then compound 3.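

In this assay the group with a five-membered aromatic ring that replaces 2,2,2-trifluoroethyl gives a 2.3-fold lower number from compound 3 to compound 4 (0.36 log units; beyond the scatter) and so shows that a change at this place can pass the scatter, which a 1.9-fold lower number from compound 1 to compound 2 (0.28 log units; within the scatter) did not show. Nothing shown here gives a cause for this step. From the compounds shown here alone, whether the group entering in compound 4 would give a similar step on compound 1 remains open. So does the effect of an amine or a carboxylic acid at this place.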